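Cytotoxicity notes on the bis-benzylidene series, compound 2 to compound 4

The compounds below may be only part of what the source reports. "The series", "measured", "known", "first", "only" and "open" are said of these compounds alone.

Compound 2 `COc1ccccc1/C=C1\CCC/C(=C\c2ccc(OC)c(OC)c2)C1=O` gives 18100 nM in an ADME assay on NHDF cells (Homo sapiens) for cytotoxicity, read by MTT assay, with a stated time of 72 h; a lower number here means a stronger inhibitor, a higher number a weaker inhibitor. Compound 1 `COc1cccc(/C=C2\CCC/C(=C\c3cc(Cl)cc(Cl)c3)C2=O)c1OC` gives 21600 nM in this assay, which sits within the scatter of compound 2. Compound 3 `COc1ccc(/C=C2\CCC/C(=C\c3ccc(OC)c(OC)c3)C2=O)c(OC)c1` reaches only the assay limit > 50000 nM in this assay. Compound 3 thus stands at the limit (the limit of > 50000 nM in this assay, at which 1 of the 3 values shown sits). Among the compounds with values here, the one measured step, an at least 2.7-fold higher number from compound 2 to compound 3 (0.44 log units; beyond the scatter), is methoxy in place of hydrogen on an aromatic carbon. Compound 4 `COc1ccc(/C=C2\CCC/C(=C\c3ccc(O)c(Cl)c3)C2=O)cc1OC` carries a different change, (3-chloro-4-hydroxyphenyl in place of 2-methoxyphenyl on a double-bonded chain carbon bound to a double-bonded ring carbon). Within the data shown here, no measured step covers this exchange, and compound 1, which also differs from compound 2 on an aryl group, lies within the scatter of compound 2. The number for compound 4 is therefore expected to stay near that of compound 2, a 1.2-fold higher number from compound 2 to compound 4 (0.08 log units; within the scatter). Compound 4 is estimated at 22000 nM, with a range of 9000 nM to 50000 nM.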

Compound 4, half-maximal inhibitory concentration: 21900 nM
For compound 4 the middle estimate is 1.0-fold (0.00 log units) above the measured one; the measured number falls inside the stated range.
By their numbers in this assay, from the lowest: compounds 2, 1 and 4 (each within the scatter of the next). At a limit, above all of these: compound 3.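

At the double-bonded chain carbon bound to a double-bonded ring carbon, 3-chloro-4-hydroxyphenyl in place of 2-methoxyphenyl gives a 1.2-fold higher number from compound 2 to compound 4 (0.08 log units; within the scatter) in this assay, so a whole-aryl exchange here leaves the number unmoved. Not every change on this aryl group behaves so: methoxy in place of hydrogen gives an at least 2.7-fold higher number from compound 2 to compound 3 (0.44 log units; beyond the scatter) and stands apart. Nothing measured here gives a cause for the new step.

As far as these compounds go, the chlorine and the hydroxyl entered together, so their separate contributions stay open. Also open, from the compounds shown here alone, is whether an amine or a carboxylic acid on this aryl group would leave the number within the scatter.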